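The compounds below may be only part of what the source reports. "The series", "measured", "known", "first", "only" and "open" are said of these compounds alone.

Compound 3 `CCCCCCC(Sc1nc(Cl)cc(Nc2nc(-c3ccc(C)cc3)cs2)n1)C(=O)O` gives 200 nM in an assay for inhibition of Polyunsaturated fatty acid 5-lipoxygenase (Homo sapiens), read by HPLC, with stated times of 15 min and 10 min (on this read-out higher numbers stand for weaker inhibition and lower numbers for stronger inhibition), the lowest of the three numbers measured. Compound 2 `O=C(O)C(Sc1nc(Cl)cc(Nc2nc(-c3ccc(Cl)cc3)cs2)n1)c1cccc2ccccc12` gives 400 nM, which lies within the scatter of compound 3. Compound 1 `CCC(Sc1nc(Cl)cc(Nc2nc(-c3ccc(Cl)cc3)cs2)n1)C(=O)O` gives 3600 nM, beyond the scatter of compound 3. Compound 4 `CCCCCCC(Sc1nc(Cl)cc(Nc2nc(-c3cccc4ccccc34)cs2)n1)C(=O)O` differs from compound 3 by naphthalen-1-yl in place of 4-methylphenyl on an aromatic carbon. Among the measured compounds shown here, the only measured step, a 9.0-fold lower number from compound 1 to compound 2 (0.95 log units; beyond the scatter), concerned a replacement on a saturated chain carbon bound to a carbonyl carbon and a sulfur, a different position from the aromatic carbon changed here, so no measured step bears directly on this change. With nothing directly comparable, the expected step is a 1.3-fold higher number from compound 3 to compound 4 (0.10 log units; within the scatter), not beyond the scatter. Compound 4 is therefore estimated at 250 nM, with a range from 80 nM to 800 nM.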

Compound 4, half-maximal inhibitory concentration: 400 nM
Compound 4: middle estimate off by 1.6-fold (0.20 log units), on the low side; low and high end bracket the measured number.
By their numbers in this assay, from the lowest: compounds 3, 2 and 4 (each within the scatter of the next); then compound 1.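

Among the compounds shown here, this is the first step read on the aromatic carbon of the five-membered aromatic ring: in this assay, naphthalen-1-yl in place of 4-methylphenyl gives a 2.0-fold higher number from compound 3 to compound 4 (0.30 log units; within the scatter) with the rest of the molecule unchanged. A second six-membered aromatic ring at this carbon therefore leaves the number within the scatter. Nothing available accounts for this outcome. On these data alone, whether a pyridine ring or a small methyl group at this carbon would do the same remains open. So does whether this exchange gives a similar step with a different group on the saturated chain carbon, such as the ethyl of compound 1.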